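The compounds below may be only part of what the source reports. "The series", "measured", "known", "first", "only" and "open" are said of these compounds alone.

Working notes on the series: in a functional assay on HL-60 cells (Homo sapiens) for inhibition, read by CCK-8 assay, with a stated time of 48 h (on this read-out lower numbers stand for stronger inhibition and higher numbers for weaker inhibition), compound 1 (`O=C(Nc1cccc([N+](=O)[O-])c1)N1CCN(S(=O)(=O)c2sccc2-c2ccccc2Oc2ccc(O)c(O)c2)CC1`) gives 4500 nM, compound 2 (`O=C(Nc1ccc(F)cc1)N1CCN(S(=O)(=O)c2sccc2-c2ccccc2Oc2ccc(O)c(O)c2)CC1`) gives 8100 nM and compound 3 (`O=S(=O)(c1sccc1-c1ccccc1Oc1ccc(O)c(O)c1)N1CCN(C(=S)Nc2ccc(Cl)cc2)CC1`) gives 5500 nM. The position of compound 3 among these numbers is no firm rank, since the data show a 1.2-fold higher number from compound 1 to compound 3 (0.09 log units; within the scatter) and a 1.5-fold lower number from compound 2 to compound 3 (0.17 log units; within the scatter). Compound 4 (`O=[N+]([O-])c1ccc(NC(=S)N2CCN(S(=O)(=O)c3sccc3-c3ccccc3Oc3ccc(O)c(O)c3)CC2)cc1`) differs from compound 3 at one place: nitro in place of chloro on an aromatic carbon. Compound 1 also carries a nitro group, and replacing its aryl group gave a 1.8-fold higher number from compound 1 to compound 2 (0.26 log units; within the scatter). All three measured steps are small, and none leaves the scatter. No step beyond the scatter is therefore expected in this assay, and these data favour no direction. The estimated change is a 1.1-fold lower number from compound 3 to compound 4 (0.04 log units; within the scatter). For compound 4 the expected value is 5000 nM, with an estimated range of 2500 nM to 10000 nM.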

Compound 4, half-maximal inhibitory concentration: 5300 nM
The estimate for compound 4 lay 1.1-fold (0.03 log units) below the measured number; measured number inside the range.
By their numbers in this assay, from the lowest: compounds 1, 4, 3 and 2 (each within the scatter of the next).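

In this assay, within the data shown here, the first exchange at this position, on an aromatic carbon para to a large group, gives a 1.0-fold lower number from compound 3 to compound 4 (0.02 log units; within the scatter) for nitro in place of chloro. The nitro group in compound 4 therefore separates neither from the chloro compound nor from the other two aryl variants, with a 1.5-fold lower number from compound 2 to compound 4 (0.18 log units; within the scatter) and a 1.2-fold higher number from compound 1 to compound 4 (0.07 log units; within the scatter), so all four compounds remain unresolved in this assay. No supporting evidence bears on this result.

On these data alone, whether an amine or a carboxylic acid at this position would give a step beyond the scatter remains open, as only chloro and nitro are compared there directly. Also open is whether changes elsewhere would resolve the series, since the core stays the same throughout the compounds shown.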